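A few compounds are considered here, and "the series" means these few. Any claim that something is new, unique, unknown or untested is made for them only; others in the source may bear on it.

Measured compounds:
Compound 1 `O=C1COc2ccc(-c3cccc(NS(=O)(=O)c4ccc(F)cc4)c3)cc2N1C1CC1`: in a functional assay on HepG2 cells (Homo sapiens) for antiproliferative activity, read by MTT assay, with a stated time of 72 h (on this read-out higher numbers stand for weaker inhibition and lower numbers for stronger inhibition), compound 1 gives > 40000 nM, a limit of the assay.
Compound 2 `O=C1COc2ccc(-c3cccc(NS(=O)(=O)c4ccc(F)cc4)c3)cc2N1c1ccccc1`: in this assay compound 2 gives 30300 nM.
Compound 3 `COc1cccc(N2C(=O)COc3ccc(-c4cnc(Cl)c(NS(=O)(=O)c5ccc(F)cc5)c4)cc32)c1`: in this assay compound 3 gives > 40000 nM, a limit of the assay.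

For the measured compounds named here, compound 2 holds the only number in this assay; the other two values are limits, and compound 1 sits at the limit of > 40000 nM in this assay, at which 2 of the 3 values shown sit, as does compound 3. Going by the values given here, the one single-change step is an at least 1.3-fold lower number from compound 1 to compound 2 (0.12 log units; that floor lies within the scatter), with phenyl in place of cyclopropyl on an amide-type nitrogen in a ring; its floor lies within the scatter, so the direction is only weakly supported.

Compound 4 `CC(C)N1C(=O)COc2ccc(-c3cccc(NS(=O)(=O)c4ccc(F)cc4)c3)cc21` differs from compound 2 by isopropyl in place of phenyl on an amide-type nitrogen in a ring. Isopropyl, like cyclopropyl in compound 1, is a small non-aromatic group on the same nitrogen, so the step from compound 1 to compound 2 is the one that bears on it, read in reverse. That step was at most small, so the expected shift in this assay is a modest rise in the number, of a size at or near the scatter, with a real chance that only a limit is reported. Compound 4 is expected at 38000 nM, ranging from 18000 nM to 80000 nM. The expected step is a 1.3-fold higher number from compound 2 to compound 4 (0.10 log units; within the scatter).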

Compound 4, half-maximal inhibitory concentration: > 40000 nM
Compound 4: a limit, no number; the forecaster's own chance of this, stated with the estimate: 50%; middle value at least 1.0-fold (0.02 log units) away from the limit.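

At the amide-type nitrogen in the ring, isopropyl joins cyclopropyl as a second non-aromatic group that leaves this assay with a limit rather than a number, so among compound 1, compound 2 and compound 4 only the phenyl of compound 2 gives a number. The new step is an at least 1.3-fold higher number from compound 2 to compound 4 (0.12 log units; that floor lies within the scatter), so the direction of the change from phenyl to isopropyl has only weak support. The step from compound 1 to compound 4 cannot be read, and the values now gather at a single ceiling: the limit of > 40000 nM in this assay, at which 3 of the 4 values shown sit.

Still open, as far as these compounds go, is whether any group on this nitrogen gives a number clearly beyond the scatter from the limit, as a single number with a floor inside the scatter does not yet separate phenyl from isopropyl or cyclopropyl. A benzyl group or a dimethylaminoethyl chain on the same nitrogen, with the rest of compound 2 unchanged, would show whether this position can move the read-out at all.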